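Working notes: trifluoromethyl in place of ethyl

A few compounds are considered here, and "the series" means these few. Any claim that something is new, unique, unknown or untested is made for them only; others in the source may bear on it.

Values in a functional assay on DU-145 cells (Homo sapiens) for inhibition, read by CCK-8 assay, with a stated time of 72 h (on this read-out lower numbers stand for stronger inhibition and higher numbers for weaker inhibition), so far:
- compound 1 `O=C(/C=C/c1cccnc1)NCCCCc1ccc(S(=O)(=O)Nc2ccccc2)cc1` gives 47.9 nM
- compound 2 `O=C(/C=C/c1cccnc1)NCCCc1cccc(S(=O)(=O)Nc2ccccc2)c1` gives 165 nM
- compound 3 `CCc1ccc(NS(=O)(=O)c2cccc(CCCCCCNC(=O)/C=C/c3cccnc3)c2)cc1` gives 40.1 nM

Compound 3 (40.1 nM) and compound 1 (47.9 nM) stand level within the scatter. Compound 2 (165 nM) carries a number higher than that of compound 3, and this gap lies beyond the scatter. Among the measured compounds shown here, the three compounds differ from one another in more than one place, so no measured pair isolates a single change and no pattern is claimed.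

Compound 4 `O=C(/C=C/c1cccnc1)NCCCCCCc1cccc(S(=O)(=O)Nc2ccc(C(F)(F)F)cc2)c1` is the next entry. It departs from compound 3 at one place, with trifluoromethyl in place of ethyl on an aromatic carbon, para to a large group (trifluoromethyl in place of ethyl on an aromatic carbon).

For the measured compounds named here, the data hold no measured example of this swap, so any expectation in this assay is weakly founded. A step within the scatter is expected, leaning slightly toward a higher number. The expected step is a 1.4-fold higher number from compound 3 to compound 4 (0.14 log units; within the scatter) and it is estimated to stay small. The upper end of the range is kept near compound 2 (165 nM) to reflect that uncertainty. For compound 4 the estimated value is 55 nM with a range from 18 nM to 170 nM expected.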

Compound 4, half-maximal inhibitory concentration: 1410 nM
Compound 4: middle estimate off by 26-fold (1.41 log units), on the low side; measured number above the stated range.
By their numbers in this assay, from the lowest: compounds 3 and 1 (each within the scatter of the next); then compound 2; then compound 4.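

In this assay, among the compounds shown here, trifluoromethyl in place of ethyl on an aromatic carbon, para to a large group, gives a 35-fold higher number from compound 3 to compound 4 (1.55 log units; beyond the scatter) and provides the first single-place comparison. The earlier compounds shown here differed in more than one place, whereas this pair shows that the outcome at this position can depend strongly on the group it carries. The exchange brings in no ring, hydrogen-bond donor, hydrogen-bond acceptor or net charge, so these counted features do not distinguish the two groups, yet the step is large; no measurement shown bears on its cause.

The compounds shown leave open whether this step is particular to trifluoromethyl or whether other groups on this carbon, such as methyl, methoxy, chlorine or a nitrile, would give a similar number. For the compounds shown here, they also leave open whether the same exchange would produce a step of similar size with a shorter chain on the shared core, since this one pair offers the only reading of the change.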